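Swapping the thiophene of compound 1 for a methylpyrazole

The source may report more compounds than this note shows. Statements on the series, on what has been measured and on what is new or still open speak of the compounds shown alone.

Compound 1 has the structure `c1csc(-c2ccccc2OCC2=NCCN2)c1`. In a functional assay for activation of Alpha-1B adrenergic receptor (Homo sapiens), read by calcium flux (a higher number here means that more compound is needed for the effect, a lower number that less compound is needed), compound 1 gives 3.98 nM, the lowest of the three numbers measured here. Compound 2, `c1ccc(-c2ccoc2)c(OCC2=NCCN2)c1`, gives 5.01 nM, and compound 3, `c1ccc(-c2ccns2)c(OCC2=NCCN2)c1`, gives 12.6 nM. Compound 4, `Cn1nccc1-c1ccccc1OCC1=NCCN1`, has not yet been measured. It differs from compound 1 in one place: 1-methyl-1H-pyrazol-5-yl in place of thiophen-2-yl on an aromatic carbon.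

Two measured steps start from the same compound 1 and change the same group. The step of a 1.3-fold higher number from compound 1 to compound 2 (0.10 log units; within the scatter) shows that one five-membered ring with a single hetero atom can replace another without a change beyond the scatter. The step of a 3.2-fold higher number from compound 1 to compound 3 (0.50 log units; beyond the scatter) shows that a five-membered ring with two hetero atoms costs a modest amount of potency. The change to compound 4 also brings in a ring with two hetero atoms, together with a methyl group, so the closer guide is the step to compound 3. A modest rise in the number is therefore expected, with the step of a 2.5-fold higher number from compound 1 to compound 4 (0.40 log units; beyond the scatter) as the expectation. Compound 4 is estimated to give 10 nM in this assay, within the range 4 nM to 30 nM.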

Compound 4, half-maximal effective concentration: < 100000 nM
Compound 4 ended at the assay's limit; the forecaster's own chance of this, stated with the estimate: 2%; the middle value does not contradict the limit.
By their numbers in this assay, from the lowest: compounds 1 and 2 (each within the scatter of the next); then compound 3.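

In this assay compound 4 gives < 100000 nM, which is a limit of the assay and not a number. The steps to compound 4 from compound 1, compound 2 and compound 3 cannot be read: the limit of < 100000 nM in this assay, at which 1 of the 4 values shown sits.

No compound shown carries the pyrazole ring without its methyl group, so whether that methyl group matters to the result for compound 4 stays open.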